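The source may hold more compounds than are shown below. What is called first, only, known or untested is meant among the compounds shown, and "the series" means these compounds.

Within the data shown here, the two compounds measured so far share one core and differ only in how many methoxy groups sit on the six-membered ring. Compound 1 `COc1cccc(Sc2c[nH]c3ccc(Cl)cc23)c1` carries a single methoxy; in an assay on isolated protein for inhibition of Indoleamine 2,3-dioxygenase 1 (Homo sapiens), read by HPLC, with a stated time of 60 min, in the presence of a further agent that is not named here (on this read-out lower numbers stand for stronger inhibition and higher numbers for weaker inhibition), compound 1 gives 21000 nM. Compound 2 `COc1cc(OC)cc(Sc2c[nH]c3ccc(Cl)cc23)c1` carries a second methoxy, and in this assay compound 2 gives 7000 nM. That one change brought a 3.0-fold lower number from compound 1 to compound 2 (0.48 log units; beyond the scatter), so compound 2 stands with the lower of the two numbers, and its gap to compound 1 is beyond the scatter.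

Compound 3 `COc1cc(Sc2c[nH]c3ccc(Cl)cc23)cc(OC)c1OC` takes the same kind of change one step further: methoxy in place of hydrogen on an aromatic carbon. Among the measured compounds shown here, the only measured step that bears on this is the one from compound 1 to compound 2, where a methoxy in place of hydrogen gave a modest gain. The third methoxy is placed differently, ortho to two methoxy groups and para to a large group, so that earlier step is a guide rather than a rule. A small gain or no change beyond the scatter is expected, so compound 3 is expected to show a 1.4-fold lower number from compound 2 to compound 3 (0.15 log units; within the scatter). In this assay compound 3 is therefore estimated at 5000 nM, most likely between 2000 nM and 15000 nM.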

Compound 3, half-maximal inhibitory concentration: 40000 nM
Beside the measured number, compound 3's estimate is 8.0-fold (0.90 log units) below it; measured number outside the range, above it.
By their numbers in this assay, from the lowest: compound 2; then compounds 1 and 3 (each within the scatter of the next).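

In this assay, the methoxy that enters ortho to two methoxy groups and para to a large group brings a 5.7-fold higher number from compound 2 to compound 3 (0.76 log units; beyond the scatter) and so weakens inhibition. The same replacement of hydrogen by methoxy went the other way in the earlier step, which gave a 3.0-fold lower number from compound 1 to compound 2 (0.48 log units; beyond the scatter) and so strengthened inhibition. The effect of this change therefore depends on where the methoxy sits on the ring, and the number of methoxy groups alone does not set the result in these three compounds. Nothing available here explains why the same change reverses direction at this position.

The compounds shown leave open whether the weaker inhibition belongs to methoxy specifically or would also appear with another group at this same place, such as a hydroxyl, a fluorine, an amine or a carboxylic acid. They also leave open whether a longer chain, such as ethoxy, would change the result here, and whether this position accepts any group at all without a loss.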